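The source may hold more compounds than are shown below. What is called first, only, known or untested is meant among the compounds shown, and "the series" means these compounds.

Compound 1 is `COc1ccc(Cn2nc(Nc3cc(C)[nH]n3)c3ccccc3c2=O)cc1`. In a functional assay on MCF7 cells (Homo sapiens) for cytotoxicity (on this read-out lower numbers stand for stronger inhibition and higher numbers for weaker inhibition), compound 1 gives only a limit, > 30000 nM, not a number (the limit of > 30000 nM in this assay, at which 1 of the 3 values shown sits). Compound 2, `Cc1cc(Nc2nn(Cc3cccnc3)c(=O)c3ccccc23)n[nH]1`, gives 13400 nM in this assay. Compound 3, `Cc1cc(Nc2nn(-c3ccc(F)cc3)c(=O)c3ccccc23)n[nH]1`, gives 1600 nM. The measured steps show that changing the group on the aromatic nitrogen matters: an at least 2.2-fold lower number from compound 1 to compound 2 (0.35 log units; beyond the scatter), an at least 18-fold lower number from compound 1 to compound 3 (1.27 log units; beyond the scatter), and an 8.4-fold lower number from compound 2 to compound 3 (0.92 log units; beyond the scatter). Compound 4, `Cc1cc(Nc2nn(Cc3ccc(S(C)(=O)=O)cc3)c(=O)c3ccccc23)n[nH]1`, differs from compound 1 in one place: methylsulfonyl in place of methoxy on an aromatic carbon. For the measured compounds named here, only the step from compound 1 to compound 2 bears on a change within the benzyl group, and that gave an at least modest improvement, so a step of similar size, toward a lower number, is expected as an at least 2.0-fold lower number from compound 1 to compound 4 (0.30 log units; that floor lies within the scatter). Compound 4 is therefore expected to give about 15000 nM, within a range from 4000 nM to 60000 nM.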

Compound 4, half-maximal inhibitory concentration: 4500 nM
For compound 4 the middle estimate is 3.3-fold (0.52 log units) above the measured one; low and high end bracket the measured number.
By their numbers in this assay, from the lowest: compound 3; then compound 4; then compound 2. At a limit, above all of these: compound 1.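

In this assay, methylsulfonyl in place of methoxy gives an at least 6.6-fold lower number from compound 1 to compound 4 (0.82 log units; beyond the scatter). The earlier steps shown here replaced a whole ring or the whole group on the aromatic nitrogen, whereas this one shows that changing only the group on the six-membered ring of carbon, para to a large group, can move the number beyond the scatter. Going by these compounds, the true size of this step stays unknown, since compound 1 stands at a limit: the limit of > 30000 nM in this assay, at which 1 of the 4 values shown sits.

On these data alone, it remains open how an amine or a carboxylic acid at this place would compare. The compounds shown also cannot tell which feature of methylsulfonyl matters.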